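Anilino-triazine acrylamides: replacing the aryl ether with an amide

The compounds below may be only part of what the source reports. "The series", "measured", "known", "first", "only" and "open" are said of these compounds alone.

Working notes on the series. Among the compounds with values here, compound 1 `C=CC(=O)Nc1cccc(Nc2ncnc(Nc3ccc(-c4cccnc4)cc3)n2)c1` is the only member with a recorded result: in a functional assay on Raji cells (Homo sapiens) for antiproliferative activity, read by CCK-8 assay, with a stated time of 24 h (on this read-out higher numbers stand for weaker inhibition and lower numbers for stronger inhibition), compound 1 gives 12400 nM, a weak level of inhibition. Within the data shown here, compound 2 `C=CC(=O)Nc1cccc(Nc2ncnc(Nc3ccc(Oc4ccc(OC)cc4)cc3)n2)c1` carries the same core but in this assay compound 2 gives "not determined" (no result reported), so it stands on no number and no step between compound 2 and compound 1 can be sized. Compound 3 `C=CC(=O)Nc1cccc(Nc2ncnc(Nc3ccc(C(=O)Nc4ccccn4)cc3)n2)c1` arises from compound 2 through ((pyridin-2-yl)carbamoyl in place of 4-methoxyphenoxy on an aromatic carbon). Among the measured compounds shown here, no measured step covers this change, so nothing in the data fixes its size or direction, and a shift beyond the scatter in either sense cannot be ruled out. For the measured compounds named here, the expectation for compound 3 rests on the one reading, compound 1 at 12400 nM. Compound 3 is estimated to give about 9000 nM in this assay, within a range from 2000 nM to 40000 nM.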

Compound 3, half-maximal inhibitory concentration: 15600 nM
Compound 3: middle estimate off by 1.7-fold (0.24 log units), on the low side, and the stated range covers the measured number.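

With this result the position carries two readings, and in this assay the change from pyridin-3-yl to (pyridin-2-yl)carbamoyl gives a 1.3-fold higher number from compound 1 to compound 3 (0.10 log units; within the scatter), so the data do not separate these two groups at this place on the aromatic carbon. Compound 3 thus shows that adding the amide hydrogen and carbonyl to a pyridine-bearing group leaves the reading at the same weak level as that of compound 1, while the steps from compound 2 cannot be read. Nothing measured bears on why these two groups read alike.

Still open, as far as these compounds go, is whether the level at this place can move beyond the scatter at all. A small group such as an amine or a carboxylic acid, or a longer chain ending in a morpholine, would test this against the shared core.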